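Replacing 4-cyanophenyl with 2-nitrophenyl in the series

The source may report more compounds than this note shows. Statements on the series, on what has been measured and on what is new or still open speak of the compounds shown alone.

In a functional assay on MCF7 cells (Homo sapiens) for cytotoxicity, read by MTT assay, with a stated time of 72 h (on this read-out lower numbers stand for stronger inhibition and higher numbers for weaker inhibition), compound 2 (`N#Cc1ccc(/C=C/C(=O)Nc2cc3c(Nc4ccc(F)c(Cl)c4)ncnc3cc2O[C@H]2CCOC2)cc1`) gives 9830 nM, the lower of the two numbers available. Compound 1 (`COc1cc(/C=C/C(=O)Nc2cc3c(Nc4ccc(F)c(Cl)c4)ncnc3cc2O[C@H]2CCOC2)cc(OC)c1OC`) gives 28400 nM. Within the data shown here, compound 3 (`COc1cc2ncnc(Nc3ccc(F)c(Cl)c3)c2cc1NC(=O)/C=C/c1ccc(C#N)cc1`) is reported as "not active" (no number reported) and, having no number, supplies no step.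

The next structure is compound 4 (`O=C(/C=C/c1ccccc1[N+](=O)[O-])Nc1cc2c(Nc3ccc(F)c(Cl)c3)ncnc2cc1O[C@H]1CCOC1`), which differs from compound 2 as follows: 2-nitrophenyl in place of 4-cyanophenyl on a double-bonded chain carbon bound to a double-bonded chain carbon. Here 2-nitrophenyl stands in place of 4-cyanophenyl on a double-bonded chain carbon bound to a double-bonded chain carbon.

Among the measured compounds shown here, only one measured step bears on this change, an exchange at the same place: a 2.9-fold lower number from compound 1 to compound 2 (0.46 log units; beyond the scatter). This modest step is a single guide and cannot fix the direction for the new group. With compound 2 at 9830 nM, a step of similar or smaller size toward a higher number is expected, although a lower number is not excluded. The expected step is a 1.5-fold higher number from compound 2 to compound 4 (0.18 log units; within the scatter). The estimate for compound 4 is 15000 nM, with an expected range of 6000 nM to 40000 nM.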

Compound 4, half-maximal inhibitory concentration: 28400 nM
Compound 4: middle estimate off by 1.9-fold (0.28 log units), on the low side; the measured number falls inside the stated range.
By their numbers in this assay, from the lowest: compound 2; then compounds 1 and 4 (each within the scatter of the next).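

In this assay the exchange of 4-cyanophenyl for 2-nitrophenyl gives a 2.9-fold higher number from compound 2 to compound 4 (0.46 log units; beyond the scatter) and shows that the lower number of compound 2 does not carry over to this other substituted phenyl group. The second comparison gives no change at the digits printed from compound 1 to compound 4 (within the scatter) and places 2-nitrophenyl level with 3,4,5-trimethoxyphenyl at this place, so compound 2 alone stands apart, with steps beyond the scatter to both others. No measurement shown here explains the difference between these groups.

Going by these compounds, it remains open whether the nitrile itself or its place on the ring sets compound 2 apart, a question that 2-cyanophenyl and 4-nitrophenyl would address. On these data alone, the readings for unsubstituted phenyl or 4-aminophenyl on this chain also remain open.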